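Combined ring substituent and methyl change in a tricyclic series

The compounds below may be only part of what the source reports. "The series", "measured", "known", "first", "only" and "open" are said of these compounds alone.

Of the compounds shown here, three on a shared core have been measured in a functional assay on A549 cells (Homo sapiens) for inhibition, read by sulforhodamine B assay, with a stated time of 48 h; a lower number here means a stronger inhibitor of growth, a higher number a weaker inhibitor of growth. Compound 1 `COC(=O)[C@@]1(C)CCC=C2[C@@H]1CC[C@@H](C)[C@]2(C)Cc1c[nH]c2ccc(OC)cc12` gives 2200 nM. Compound 2 `COC(=O)[C@@]1(C)CCC=C2[C@@H]1CC[C@@H](C)[C@]2(C)Cc1c[nH]c2ccc(C(F)(F)F)cc12`, which carries trifluoromethyl in place of methoxy on an aromatic carbon, gives 15000 nM, a step of a 6.8-fold higher number from compound 1 to compound 2 (0.83 log units; beyond the scatter). Compound 3 `COC(=O)[C@@]1(C)CCC=C2[C@@H]1CC[C@@H](C)[C@]2(C)Cc1c(C)[nH]c2ccc(OC)cc12` differs from compound 1 by methyl in place of hydrogen on an aromatic carbon. Compound 3 gives 16000 nM, a step of a 7.3-fold higher number from compound 1 to compound 3 (0.86 log units; beyond the scatter). The values of compound 2 and compound 3 lie within the scatter of each other.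

Compound 4 `COC(=O)[C@@]1(C)CCC=C2[C@@H]1CC[C@@H](C)[C@]2(C)Cc1c(C)[nH]c2ccc(C(F)(F)F)cc12` has not yet been measured. It differs from compound 3 by trifluoromethyl in place of methoxy on an aromatic carbon, the same change that separates compound 1 from compound 2, since the place is described in identical words for both pairs. In this assay, among the measured compounds shown here, the expected step is one in the same direction as a 6.8-fold higher number from compound 1 to compound 2 (0.83 log units; beyond the scatter), on the assumption that the two changes act roughly independently, though with only one measured example of this change the size is uncertain and a weaker response from the already high value of compound 3 cannot be excluded. The expected step is a 3.8-fold higher number from compound 3 to compound 4 (0.57 log units; beyond the scatter). For compound 4 the estimated value is 60000 nM, with a likely range from 15000 nM to 200000 nM.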

Compound 4, concentration for 50% growth inhibition: 17000 nM
Compound 4: middle estimate off by 3.5-fold (0.55 log units), on the high side; measured number inside the range.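

In this assay, trifluoromethyl in place of methoxy on an aromatic carbon does not carry over from the core of compound 1 to the core of compound 3, where it gives a 1.1-fold higher number from compound 3 to compound 4 (0.03 log units; within the scatter), and the two steps differ: the same change on two cores in this assay, a 6.8-fold higher number (0.83 log units; beyond the scatter) from compound 1 to compound 2 and a 1.1-fold higher number (0.03 log units; within the scatter) from compound 3 to compound 4, 6.4-fold (0.81 log units) apart, beyond the scatter of two such steps. Methyl in place of hydrogen on an aromatic carbon likewise does not carry over, giving a 1.1-fold higher number from compound 2 to compound 4 (0.05 log units; within the scatter), so the two changes do not add in these four compounds: the same change on two cores in this assay, a 7.3-fold higher number (0.86 log units; beyond the scatter) from compound 1 to compound 3 and a 1.1-fold higher number (0.05 log units; within the scatter) from compound 2 to compound 4, 6.4-fold (0.81 log units) apart, beyond the scatter of two such steps. Among the compounds shown here, this shows only that a step measured on one core could not be transferred to the other here; it does not show the reason, nor whether other groups in these places would behave in the same way.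

Still open, on these data alone, is whether an amine or a carboxylic acid in place of the methoxy would give a different number with the added methyl present. A longer chain in place of that methyl, such as ethyl, also remains to be compared on both cores.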